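This account rests on a few compounds, and the source may have more. Where it says the series, first, only, none or still open, it means among the compounds named here.

Going by the values given here, the three compounds measured so far share one core and differ at two places. Compound 1 `CC(C)c1c(C(=O)N2CCC[C@H](c3ccccc3)C2)nn(-c2ccc(F)cc2)c1CC[C@@H](O)C[C@@H](O)CC(=O)O` gives 2.1 nM in an assay on microsomes from liver for inhibition of 3-hydroxy-3-methylglutaryl-coenzyme A reductase (Rattus norvegicus); a higher number here means a weaker inhibitor, a lower number a stronger inhibitor. Compound 2 `CC(C)c1c(C(=O)N2CCC[C@H](N3CCC4C=CC=CC4C3)C2)nn(-c2ccc(F)cc2)c1CC[C@@H](O)C[C@@H](O)CC(=O)O` gives 10 nM, and compound 3 `CC(C)c1c(C(=O)N2CCC[C@H](c3ccccc3)C2)nn(-c2ccc(F)cc2)c1OC[C@@H](O)C[C@@H](O)CC(=O)O` gives 4.8 nM. Compound 3 therefore stands second highest of the three numbers, with compound 1 giving a stronger inhibition and compound 2 a weaker one.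

The unmeasured compound 4 `Cc1cccc(CN(C)C(=O)c2nn(-c3ccc(F)cc3)c(OC[C@@H](O)C[C@@H](O)CC(=O)O)c2C(C)C)c1` keeps the side chain of compound 3 and changes the amide part: methyl(3-methylbenzyl)amino in place of 3-phenylpiperidin-1-yl on a carbonyl carbon. Among the compounds with values here, of the two measured steps, only the one at the amide bears on this change: replacing the phenyl group on the piperidine gave a 4.8-fold higher number from compound 1 to compound 2 (0.68 log units; beyond the scatter), a modest loss. The other step, a 2.3-fold higher number from compound 1 to compound 3 (0.36 log units; beyond the scatter), concerns the side chain and does not speak to the amide. The change to compound 4 is a larger reshaping of the same region than the step from compound 1 to compound 2, so a step of similar, modest size towards weaker inhibition is expected, a 2.5-fold higher number from compound 3 to compound 4 (0.40 log units; beyond the scatter). Compound 4 is therefore estimated at 12 nM, with a range of 4 nM to 35 nM.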

Compound 4, half-maximal inhibitory concentration: 37 nM
Compound 4: the middle estimate sits 3.1-fold (0.49 log units) below what was measured; the measured number lies above the stated range.
By their numbers in this assay, from the lowest: compound 1; then compound 3; then compound 2; then compound 4.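

In this assay, replacing the 3-phenylpiperidin-1-yl group on the carbonyl carbon with methyl(3-methylbenzyl)amino gives a 7.7-fold higher number from compound 3 to compound 4 (0.89 log units; beyond the scatter). The earlier step at this amide, a 4.8-fold higher number from compound 1 to compound 2 (0.68 log units; beyond the scatter), replaced only the phenyl group on the piperidine, whereas this one removes the non-aromatic ring and its defined stereocentre while an aromatic ring of six carbons remains, and keeping that aromatic ring does not hold the number at the level of compound 3. Nothing available explains this rise.

The step changes several features at once, so the compounds shown do not separate the loss of the piperidine ring from the added methyl on the benzyl ring. A plain benzyl group, or an ethyl group in place of the methyl on the amide nitrogen, would bear on that question.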